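Adding a Third Methoxy Group to a Pyrazole Chalcone

A few compounds are considered here, and "the series" means these few. Any claim that something is new, unique, unknown or untested is made for them only; others in the source may bear on it.

Three compounds have been measured in a functional assay on 786-0 cells (Homo sapiens) for inhibition, read by sulforhodamine B assay, with a stated time of 48 h; on this read-out higher numbers stand for lower toxicity in this test and lower numbers for higher toxicity in this test:

Compound 1, `COc1cc(-c2cc(/C=C/C(=O)c3ccc(N)cc3)[nH]n2)cc(OC)c1OC`, gives 27600 nM.
Compound 2, `COc1ccc(C(=O)/C=C/c2cc(-c3cc(OC)c(OC)c(OC)c3)n[nH]2)cc1OC`, gives 5820 nM.
Compound 3, `COc1ccc(-c2cc(/C=C/C(=O)c3ccc(N)cc3)[nH]n2)cc1OC`, gives 10800 nM.

Compound 4, `COc1cc(C(=O)/C=C/c2cc(-c3cc(OC)c(OC)c(OC)c3)n[nH]2)cc(OC)c1OC`, is not yet measured.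

Compound 3 and compound 1 differ in one place: methoxy in place of hydrogen on an aromatic carbon. This brought a 2.6-fold higher number from compound 3 to compound 1 (0.41 log units; beyond the scatter), so compound 1 is somewhat less toxic to these cells than compound 3. Compound 1 and compound 2 differ in another single place, and there the number moved the other way, a 4.7-fold lower number from compound 1 to compound 2 (0.68 log units; beyond the scatter). The difference between the cores of compound 2 and compound 3 is not broken down here; their two values lie within the usual scatter of each other, so no order between them can be claimed.

Compound 4 differs from compound 2 in one place: methoxy in place of hydrogen on an aromatic carbon. The surroundings of that place read the same as for the change from compound 3 to compound 1, so this is the same change, made on a different core. Among the compounds with values here, its only precedent is a 2.6-fold higher number from compound 3 to compound 1 (0.41 log units; beyond the scatter), and on that basis a step of similar size, a 2.2-fold higher number from compound 2 to compound 4 (0.35 log units; beyond the scatter), is expected from compound 2 to compound 4, with a wide margin because only one such pair exists. Compound 4 is therefore estimated at 13000 nM, most likely between 5000 nM and 35000 nM.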

Compound 4, concentration lethal to 50% of the cells: 6760 nM
Compound 4: middle estimate off by 1.9-fold (0.28 log units), on the high side; the measured number falls inside the stated range.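

On the core of compound 2, the added methoxy group brought a 1.2-fold higher number from compound 2 to compound 4 (0.07 log units; within the scatter) in this assay, so on this core the result cannot be told apart from no change at all. Set beside the earlier case, the two steps cannot be told apart from each other either: the same change on two cores in this assay, a 2.6-fold higher number (0.41 log units; beyond the scatter) from compound 3 to compound 1 and a 1.2-fold higher number (0.07 log units; within the scatter) from compound 2 to compound 4, 2.2-fold (0.34 log units) apart, within the scatter of two such steps. The pair therefore shows that this methoxy group need not give a step beyond the scatter on every core, but it does not show that the two cores respond differently, and two pairs are too few to set a rule for carrying the change to other cores in this series.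

The compounds shown leave open what a different group would do at this same place on the aromatic ring, such as a hydroxyl group, a chlorine atom or an ethoxy group, all of which would test whether methoxy itself matters here. They also leave open whether the same change would read alike on further cores, for example one with a carboxylic acid in place of the amine of compound 1, or on cells other than those tested here.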